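Swapping the saturated ring for fluorophenyl on the amide

This account rests on a few compounds, and the source may have more. Where it says the series, first, only, none or still open, it means among the compounds named here.

Compound 3 `COc1ccc(-c2cnc(NC(=O)C3CCOCC3)n2C)cc1` is examined in a toxicity assay on THP-1 cells (Homo sapiens) for inhibition; on this read-out higher numbers stand for lower toxicity in this test and lower numbers for higher toxicity in this test. In this assay compound 3 reaches only a limit, > 100000 nM. Compound 1 `COc1ccc(-c2cnc(NC(=O)c3cccc(OC)c3)n2C)cc1` also reaches only a limit, > 100000 nM. Compound 2 `Cn1c(-c2ccc(F)cc2)cnc1NC(=O)c1ccc(F)cc1` likewise gives only a limit, > 100000 nM. Going by the values given here, the single measured step that changes the same carbonyl position, a step that the two limits leave unreadable from compound 1 to compound 3, has no readable size because both of its ends sit at the limit of > 100000 nM in this assay, at which 3 of the 3 values shown sit. Compound 4 `COc1ccc(-c2cnc(NC(=O)c3ccc(F)cc3)n2C)cc1` differs from compound 3 in one place: 4-fluorophenyl in place of oxan-4-yl on a carbonyl carbon. Among the compounds with values here, no measured step therefore gives a size for this change, and no shift beyond the scatter is expected in this assay; the likeliest outcome is again a limit. Compound 4 is expected at 150000 nM, within 80000 nM to 300000 nM. The expected step is a step that the limit leaves unreadable from compound 3 to compound 4.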

Compound 4, half-maximal cytotoxic concentration: >= 50000 nM
Compound 4 was reported as a limit; the forecaster's own chance of this, stated with the estimate: 85%; the middle value lies beyond the limit too.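

Going by these compounds alone, compound 1, compound 2, compound 3 and compound 4 all give only limits in this assay, and no step from compound 4 to the others can be read. The compounds shown leave open whether swapping these groups changes toxicity at all.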